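This account rests on a few compounds, and the source may have more. Where it says the series, first, only, none or still open, it means among the compounds named here.

Of the compounds shown here, three on one shared core have been tested in a functional assay on NCI-H292 cells (Homo sapiens) for cytotoxicity, read by MTT assay, with a stated time of 72 h, tested at 10 ug/mL; on this read-out higher numbers stand for more inhibition of growth at the one concentration tested and lower numbers for less inhibition of growth. Compound 1 `O=C1NC(=S)/C(=C/c2ccc(Br)cc2)S1` gives 36.5% in this assay. Compound 2 `O=C1NC(=S)/C(=C/c2cccc(Br)c2)S1` gives 42.4%. Compound 3 `O=C1NC(=S)/C(=C/c2ccccc2Br)S1` gives 36.9%. Compound 3 thus stands second highest of the three numbers, but its gap to compound 1 and its gap to compound 2 both lie within the usual scatter, so the three read as alike. Compound 4 `O=C1NC(=S)/C(=C/c2ccccc2Cl)S1` has not yet been measured. The change from compound 3 to compound 4 is chloro in place of bromo on an aromatic carbon. Within the data shown here, no measured pair shows what such a change does on this core. In this assay the expected step is a number 0.9 percentage points lower from compound 3 to compound 4 (within the scatter), in neither direction beyond the scatter. For compound 4 the expected value in this assay is 36%, with a range from 26% to 46%.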

Compound 4, percent growth inhibition at one concentration: 45%
Estimate against measurement, compound 4: 9 percentage points below; the range from low to high includes it.
By their numbers in this assay, from the lowest: compounds 1, 3, 2 and 4 (each within the scatter of the next).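

Chloro in place of bromo on an aromatic carbon, ortho to a group of 8 heavy atoms, is the only one-place step on this core in this assay and gives a number 8.1 percentage points higher from compound 3 to compound 4 (within the scatter). Exchanging these two halogens at this position therefore shows no effect that can be separated from the scatter. No measurement here offers an explanation for this step. Still open, from the compounds shown here alone, is whether an amine or a carboxylic acid on this aromatic carbon would give a step beyond the scatter.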